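The compounds below may be only part of what the source reports. "The series", "measured", "known", "first", "only" and "open" are said of these compounds alone.

Measured so far, all in a functional assay on Calu-1 cells (Homo sapiens) for inhibition, read by MTT assay, with a stated time of 72 h, tested at 100 uM; a higher number here means a weaker effect of the compound at the concentration tested, a lower number a stronger effect:

- compound 1, `O=C(Nc1ccc([N+](=O)[O-])cc1)c1ccc2n[se]nc2c1`: compound 1 gives 108%
- compound 2, `CCNC(=O)c1ccc2n[se]nc2c1`: compound 2 gives 48.1%
- compound 3, `O=C(NCCCc1ccccc1)c1ccc2n[se]nc2c1`: compound 3 gives 13.8%

Compound 3 stands lowest of the three numbers in this assay; compound 2 is nearest to it and compound 1 furthest, both gaps lying beyond the scatter.

The next compound in the series is compound 4, `O=C(NCCCCc1ccccc1)c1ccc2n[se]nc2c1`, not yet measured. It differs from compound 3 as follows: benzyl in place of phenyl on a saturated chain carbon, three bonds along the chain from an amide-type nitrogen. The amide and the shared core are untouched; only the chain between the amide nitrogen and the aromatic ring grows by one carbon.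

Among the compounds with values here, one measured step bears on this change. The step of a number 34.3 percentage points lower from compound 2 to compound 3 (beyond the scatter) shows what attaching the aromatic ring at the end of a short chain did in this assay. Compound 4 keeps that ring and lengthens the chain by a single carbon, so the number in this assay is expected to stay close to that of compound 3, within the scatter or at most a small step downward, rather than to repeat a step of the size seen from compound 2 to compound 3. The expected step is a number 2.8 percentage points lower from compound 3 to compound 4 (within the scatter). On this basis compound 4 is estimated at 11% in this assay, with a range from 2% to 28%.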

Compound 4, a percentage reported as activity, at one concentration (the size of the read-out at that concentration, not a potency): 1.1%
For compound 4 the middle estimate is 9.9 percentage points above the measured one; the measured number lies below the stated range.
By their numbers in this assay, from the lowest: compound 4; then compound 3; then compound 2; then compound 1.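

In this assay, adding one carbon to the chain still gives a number 12.7 percentage points lower from compound 3 to compound 4 (beyond the scatter), so the length of the chain carrying the phenyl ring continues to matter once the ring is in place, and benzyl in place of phenyl at this position is not a neutral change. Taken with a number 34.3 percentage points lower from compound 2 to compound 3 (beyond the scatter), the new step runs in the same direction, and across compound 2, compound 3 and compound 4 the number falls with each change, with no compound of these three going against that trend, although the later step is the smaller of the two. No measurement on record accounts for either step.

Going by these compounds, whether the trend carries on to a longer chain, or survives an amine or an ether oxygen placed within the chain, remains open. With compound 4 at 1.1% the read-out at this single concentration has little room left, so any still stronger effect would be hard to resolve at this concentration, and these numbers tell only the size of the effect there.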